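Replacing the trifluoropropyl amine with a second difluoroaniline

A few compounds are considered here, and "the series" means these few. Any claim that something is new, unique, unknown or untested is made for them only; others in the source may bear on it.

Measured so far:
compound 1 `Fc1cc(C(F)(F)F)ccc1Nc1nc2nonc2nc1Nc1ccc(C(F)(F)F)cc1F` — < 1000 nM
compound 2 `Fc1ccccc1Nc1nc2nonc2nc1NCCC(F)(F)F` — > 100000 nM

In an assay on mitochondria from L6 cells (Rattus norvegicus) for activation, with a stated time of 90 min (on this read-out higher numbers stand for an effect only at larger amounts of compound and lower numbers for an effect already at smaller amounts), compound 1 is reported only as a limit, < 1000 nM (the limit of < 1000 nM in this assay, at which 1 of the 2 values shown sits). Compound 2 is likewise reported only as a limit, > 100000 nM (the limit of > 100000 nM in this assay, at which 1 of the 2 values shown sits), and so stands at the far end of the two values shown. Compound 3 `Fc1ccccc1Nc1nc2nonc2nc1Nc1cccc(F)c1F` is not yet measured; it differs from compound 2 by 2,3-difluorophenyl in place of 3,3,3-trifluoropropyl on a nitrogen on an aromatic ring. For the measured compounds named here, no measured step covers this change, yet compound 1 sits at the opposite limit, so a step toward smaller amounts, well beyond the scatter, is expected. The expected step is an at least 50-fold lower number from compound 2 to compound 3 (1.69 log units; beyond the scatter). Compound 3 is estimated at 2000 nM, within 300 nM to 20000 nM.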

Compound 3, half-maximal effective concentration: 500 nM
For compound 3 the middle estimate is 4.0-fold (0.60 log units) above the measured one, within the range that was stated.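

At this nitrogen on an aromatic ring the change is large: in this assay, 2,3-difluorophenyl in place of 3,3,3-trifluoropropyl gives an at least 200-fold lower number from compound 2 to compound 3 (2.30 log units; beyond the scatter). Compound 3 gives 500 nM. The starting point of that step is a limit, held by compound 2: the limit of > 100000 nM in this assay, at which 1 of the 3 values shown sits.

Whether the step comes from the aromatic ring or from its fluorines stays open, since an unsubstituted phenyl or a longer alkyl chain at this nitrogen is not among the compounds shown. For the compounds shown here, compound 1 differs from compound 3 in more than one place, so no step between them can be read.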